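The source may report more compounds than this note shows. Statements on the series, on what has been measured and on what is new or still open speak of the compounds shown alone.

In a functional assay on OVCAR-3 cells (Homo sapiens) for inhibition, read by sulforhodamine B assay, with a stated time of 48 h, tested at 10 uM (a lower number here means less inhibition, a higher number more inhibition at the concentration tested (going by the name of the read-out)), compound 1 `Brc1cn2ccnc2c(-c2ccc3ncn(C4CCCCC4)c3c2)n1` gives 15.8%, and compound 2 `Brc1ccc(-c2cn3ccnc3c(-c3ccc4ncn(C5CCCCC5)c4c3)n2)cc1` gives 26.3%. Within the data shown here, of the two numbers in this assay, compound 2 stands highest, and the single measured step, a number 10.5 percentage points higher from compound 1 to compound 2 (beyond the scatter), separates it from compound 1 by more than the scatter.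

Compound 3 `Fc1ccccc1-c1cn2ccnc2c(-c2ccc3ncn(C4CCCCC4)c3c2)n1` has not yet been measured in this assay. It differs from compound 2 in one place: 2-fluorophenyl in place of 4-bromophenyl on an aromatic carbon. Among the measured compounds shown here, the only measured step exchanges bromo on an aromatic carbon for 4-bromophenyl at this same place, so it speaks to putting an aromatic ring there at all, not to swapping one such ring for another. For the measured compounds named here, no measured step bears directly on the replacement of 4-bromophenyl by 2-fluorophenyl, so there is no ground for expecting a step beyond the scatter in either direction; the step from compound 2 to compound 3 is estimated as a number 2.3 percentage points lower from compound 2 to compound 3 (within the scatter). Compound 3 is therefore expected to give about 24% in this assay, within a range from 8% to 42%.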

Compound 3, a percentage reported as inhibition, at one concentration (the size of the read-out at that concentration, not a potency): 0.17%
Estimate against measurement, compound 3: 23.8 percentage points above, and the stated range ends above it.
By their numbers in this assay, from the lowest: compound 3; then compound 1; then compound 2.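

In this assay, swapping one phenyl ring for another at this aromatic carbon is not a neutral exchange: the change to 2-fluorophenyl gives a number 26.1 percentage points lower from compound 2 to compound 3 (beyond the scatter), even though both groups have the same count of heavy atoms and one six-membered aromatic ring of carbon only. Placing an aromatic ring on this carbon therefore does not raise the number by itself, as the earlier step alone might have suggested, since 2-fluorophenyl in place of bromo gives a number 15.6 percentage points lower from compound 1 to compound 3 (beyond the scatter), and so the direction of the change depends on which ring is attached. Nothing available gives a reason for this fall.

Because 4-bromophenyl and 2-fluorophenyl differ in both the halogen and its place on the phenyl ring, these compounds cannot show which of the two differences matters. They also leave open how an unsubstituted phenyl ring, or an amine on this same aromatic carbon, would compare with the groups shown.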